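A Configuration Change Read Against an Assay Limit

The source may hold more compounds than are shown below. What is called first, only, known or untested is meant among the compounds shown, and "the series" means these compounds.

Compound 1 (`O=C(O)[C@H](CO)NC(=O)[C@H]1C[C@H](O)CN1`) and compound 2 (`O=C(N[C@H](CO)C(=O)O)[C@@H]1C[C@H](O)CN1`) have both been read in an ADME assay for metabolic stability, read by HPLC, in simulated intestinal fluid, with a stated time of 12 h, at pH 6.8 (on this read-out higher numbers stand for a longer-lived compound and lower numbers for a shorter-lived compound), and neither gives a number there. Compound 1 gives > 12 h as a limit of the assay. Compound 2 gives > 12 h as a limit of the assay too, and that limit is all that places it. Among the measured compounds shown here, the one measured step is a step that the two limits leave unreadable from compound 1 to compound 2 and its size cannot be told. Two things bear on what follows: the limit of > 12 h in this assay, at which 2 of the 2 values shown sit, and the fact that compounds 1 and 2 differ only in the configuration as drawn together.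

Compound 3 (`O=C(O)[C@H](CO)NC(=O)[C@@H]1C[C@@H](O)CN1`) follows from compound 2 through the two compounds have the same atoms and bonds and differ only in configuration as drawn: 2 of 3 stereo elements differ; a stereocentre at a saturated chain carbon is drawn R in compound 2 and S in compound 3; a stereocentre at a saturated ring carbon is drawn S in compound 2 and R in compound 3 and keeps the same atoms and bonds. This change again concerns a stereocentre at a saturated chain carbon and one at a saturated ring carbon. Compound 1 and compound 2 differ at centres of those kinds and share the same limit, so no step beyond the scatter is expected, although no measured size supports this. The expected step is a step that the limit leaves unreadable from compound 2 to compound 3 and no direction is foreseen for it. Compound 3 is estimated at 16 h with a range from 12 h to 30 h and is expected to be reported most likely as a limit only.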

Compound 3, half-life: > 12 h
Compound 3: only a limit was reported; the forecaster's own chance of this, stated with the estimate: 85%; the middle value lies beyond the limit too.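

In this assay compound 3 gives > 12 h, which is a limit of the assay. No step among compound 1, compound 2 and compound 3 can be read, and the limit is what stands in the way: the limit of > 12 h in this assay, at which 3 of the 3 values shown sit.

The compounds shown leave open how long any of the three lasts and whether their configurations differ in half-life at all.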